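This account rests on a few compounds, and the source may have more. Where it says the series, first, only, none or still open, it means among the compounds named here.

Measured so far in a toxicity assay on HepG2 cells (Homo sapiens) for cytotoxicity, read by MTT assay, with a stated time of 48 h; on this read-out lower numbers stand for higher toxicity in this test and higher numbers for lower toxicity in this test:

Compound 1 `CN1CCN(S(=O)(=O)c2ccc(-c3ccc4c(Nc5ccc(OCc6cccc(F)c6)c(Cl)c5)nccc4c3)cc2)CC1`. In this assay compound 1 gives > 15 uM, which is a limit of the assay.
Compound 2 `CN1CCCN(S(=O)(=O)c2ccc(-c3ccc4c(Nc5ccc(OCc6cccc(F)c6)c(Cl)c5)nccc4c3)cc2)CC1`. In this assay compound 2 gives > 15 uM, also a limit of the assay.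
Compound 3 `CN1CCCN(S(=O)(=O)c2ccc(C3=CC4N=CN=C(Nc5ccc(OCc6cccc(F)c6)c(Cl)c5)C4S3)cc2)CC1`. In this assay compound 3 gives > 15 uM, again a limit of the assay.

Compound 2 and compound 1 share one core and differ only by 4-methylpiperazin-1-yl in place of 4-methyl-1,4-diazepan-1-yl on a sulfonyl sulfur. The step that the two limits leave unreadable from compound 2 to compound 1 cannot be sized, because of the limit of > 15 uM in this assay, at which 3 of the 3 values shown sit. Compound 3 carries a different core; the difference between the two cores is not broken down here.

Compound 4 `CN1CCN(S(=O)(=O)c2ccc(C3=CC4N=CN=C(Nc5ccc(OCc6cccc(F)c6)c(Cl)c5)C4S3)cc2)CC1` has not yet been measured in this assay. It differs from compound 3 by 4-methylpiperazin-1-yl in place of 4-methyl-1,4-diazepan-1-yl on a sulfonyl sulfur, the same change at the same place as between compound 2 and compound 1. Nothing among the three measured compounds reaches a readable number, so the series gives no sign of this change moving the read-out.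

Compound 4 is expected to come out at about 30 uM, within 15 uM to 100 uM. This expectation rests on compound 3 sitting at > 15 uM, a limit of the assay. The step from compound 3 to compound 4 is estimated as a step that the limit leaves unreadable from compound 3 to compound 4, most likely leaving compound 4 at the same limit.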

Compound 4, half-maximal toxic concentration: > 15 uM
Compound 4 was reported as a limit; the forecaster's own chance of this, stated with the estimate: 85%; the middle value does not contradict the limit.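

No step can be read from compound 3 to compound 4 in this assay, because both compounds sit at the same limit of the assay: the limit of > 15 uM in this assay, at which 4 of the 4 values shown sit.

The compounds shown leave open whether 4-methylpiperazin-1-yl in place of 4-methyl-1,4-diazepan-1-yl on a sulfonyl sulfur moves the read-out at all, and where compound 1, compound 2, compound 3 and compound 4 lie past that limit.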